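Alkyl variation on the double-bonded nitrogen: notes on compound 4

A few compounds are considered here, and "the series" means these few. Any claim that something is new, unique, unknown or untested is made for them only; others in the source may bear on it.

Measured so far in a functional assay on the whole organism (blood, strain Wistar-Okamoto) with Rattus norvegicus as the target, with a stated time of 5 days; on this read-out lower numbers stand for an effect already at smaller amounts and higher numbers for an effect only at larger amounts of compound:
compound 1, `CC(C)(C)C/N=C(\NC#N)Nc1ccncc1`: 5 mg/kg
compound 2, `CCC(CC)/N=C(\NC#N)Nc1ccncc1`: 2.5 mg/kg
compound 3, `CC(C)(C)/N=C(\NC#N)Nc1ccncc1`: 2.5 mg/kg

Compound 2 sits level with compound 3 at the digits shown, and the step of a 2.0-fold lower number from compound 1 to compound 2 (0.30 log units; within the scatter) lies within the scatter, as does a 2.0-fold lower number from compound 1 to compound 3 (0.30 log units; within the scatter) and no change at the digits printed from compound 2 to compound 3 (within the scatter). Across three different alkyl groups on the double-bonded nitrogen, then, nothing in this assay moves beyond the scatter.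

Compound 4, `CCC(CC)(CC)/N=C(\NC#N)Nc1ccncc1`, is not yet measured. Relative to compound 2 the change is ethyl in place of hydrogen on a saturated chain carbon bound to a double-bonded nitrogen and two saturated chain carbons. The step from compound 3 to compound 4 is also a pure enlargement of the alkyl group on that nitrogen. Going by the values given here, the steps that bear on it, no change at the digits printed from compound 2 to compound 3 (within the scatter) and a 2.0-fold lower number from compound 1 to compound 2 (0.30 log units; within the scatter), were both within the scatter, so no step beyond the scatter is expected in this assay; the estimated step is no change at the digits printed from compound 2 to compound 4 (within the scatter). Compound 4 is expected to come out at 2.5 mg/kg, with a range from 1.25 mg/kg to 5 mg/kg.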

Compound 4, minimum effective dose: 2.5 mg/kg
Compound 4: the middle estimate sits on the measured number at the digits printed, and the stated range covers the measured number.
By their numbers in this assay, from the lowest: compounds 2, 3, 4 and 1 (each within the scatter of the next).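

In this assay, the step of no change at the digits printed from compound 2 to compound 4 (within the scatter) shows that this position accepts ethyl in place of hydrogen on a saturated chain carbon bound to a double-bonded nitrogen and two saturated chain carbons, with no move beyond the scatter. The earlier steps shown here only exchanged one alkyl group for another, whereas this one adds ethyl to the group carried by compound 2 and so extends the range of alkyl groups tested on that nitrogen. The compounds shown offer no measurement that would explain this result.

From the compounds shown here alone, it remains open whether the same holds for a longer chain, such as n-octyl, or for a group that is not purely hydrocarbon, such as an amine or a carboxylic acid at the end of the chain. With every listed step within the scatter, the compounds shown do not identify any change at this position that moves the read-out.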